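The source may hold more compounds than are shown below. What is called first, only, known or untested is meant among the compounds shown, and "the series" means these compounds.

Values so far in a functional assay on B16-F10 cells (Mus musculus) for inhibition, read by MTT assay, with a stated time of 72 h (on this read-out lower numbers stand for stronger inhibition and higher numbers for weaker inhibition), are as follows.
- compound 1 `CC1(C)CC(NC(=S)Nc2cccc(C#N)c2)c2cc(Br)ccc2O1` gives 7000 nM
- compound 2 `CC1(C)CC(NC(=O)Nc2ccccc2Cl)c2cc(F)ccc2O1` gives "not determined" (no result reported)
- compound 3 `CC1(C)CC(NC(=O)Nc2ccccc2)c2cc(Cl)ccc2O1` gives "not determined" (no result reported)

Compound 3 has no single number to stand on. Among the measured compounds shown here, compound 2 is in the same position, so compound 1 supplies the only numerical value in the set. For the measured compounds named here, no step between two measured compounds that differ in one place is available, and the series gives no direct guide to the effect of any single substitution.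

The next compound for reading is compound 4 (`CC1(C)CC(NC(=O)Nc2ccccc2Cl)c2cc(Cl)ccc2O1`). The structural change from compound 3 is chloro in place of hydrogen on an aromatic carbon and amounts to chloro in place of hydrogen on an aromatic carbon, taking phenyl to 2-chlorophenyl.

With no number for compound 3, the size of this step cannot be calculated. The working expectation in this assay is no step beyond the scatter and no favoured direction, although this rests on the small size of the change and not on any measured pair. The estimate therefore leans on compound 1 at 7000 nM as the sole numerical reference, and the range is kept wide. For compound 4 the expected value is 8000 nM with an estimated range of 2500 nM to 30000 nM in this assay.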

Compound 4, half-maximal inhibitory concentration: 20000 nM
Beside the measured number, compound 4's estimate is 2.5-fold (0.40 log units) below it, and the stated range covers the measured number.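

In this assay compound 3 has no single number, so compound 4 at 20000 nM gives no readable step from it. The compounds shown leave open what the change from phenyl to 2-chlorophenyl does to inhibition on the shared core. No supporting data bear on the result for compound 4.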